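Removing the vinyloxy group from compound 2

A few compounds are considered here, and "the series" means these few. Any claim that something is new, unique, unknown or untested is made for them only; others in the source may bear on it.

Measured compounds:
compound 1, `c1cncc(N2CCCNCCC2)c1`, 78%
compound 2, `C=COc1cc(N2CCCNCCC2)cnc1Br`, 90%
compound 3, `COc1ccc(N2CCCNCC2)cn1`, 88%

Of the compounds shown here, three have been measured in an assay on HEK293 cells with Neuronal acetylcholine receptor; alpha4/beta2 (Homo sapiens) as the target, read by FLIPR and calcium flux; on this read-out higher numbers stand for larger maximal responses and lower numbers for smaller maximal responses. Compound 1, `c1cncc(N2CCCNCCC2)c1`, reaches 78%. Compound 2, `C=COc1cc(N2CCCNCCC2)cnc1Br`, reaches 90%, and compound 3, `COc1ccc(N2CCCNCC2)cn1`, reaches 88%. Among these three numbers compound 2 stands highest, but its gap to compound 3 lies within the scatter, so the two cannot be ranked against each other; only compound 1 lies beyond the scatter below compound 2.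

Compound 4, `Brc1ccc(N2CCCNCCC2)cn1`, has not yet been measured in this assay. It differs from compound 2 in one place: hydrogen in place of vinyloxy on an aromatic carbon. The vinyloxy group of compound 2 leaves and a hydrogen atom enters on the aromatic carbon, ortho to the bromo group, two atoms from the ring nitrogen and meta to the group of 8 heavy atoms.

Within the data shown here, no measured pair shows this particular change, so the size of the step has to be inferred from the spread of the three numbers, which is narrow. The account expects for compound 4 a small step of a number 6 percentage points lower from compound 2 to compound 4 (within the scatter), downward, and not clearly beyond the scatter. The estimated value for compound 4 is 84%, within a range from 70% to 95%.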

Compound 4, largest response reached (reported as efficacy), in percent of the reference or control that the assay uses: 139%
Compound 4: the middle estimate sits 55 percentage points below what was measured, outside the stated range (above it).
By their numbers in this assay, from the lowest: compounds 1, 3 and 2 (each within the scatter of the next, the first and the last beyond it); then compound 4.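

In this assay, the aromatic carbon ortho to the bromo group, two atoms from the ring nitrogen and meta to the group of 8 heavy atoms proves highly sensitive to what it carries: hydrogen in place of vinyloxy gives a number 49 percentage points higher from compound 2 to compound 4 (beyond the scatter). The second step shows that bromo in place of hydrogen on an aromatic carbon of the core also matters, with a number 61 percentage points higher from compound 1 to compound 4 (beyond the scatter), so the bromo group goes with a large rise in maximal response when the vinyloxy group is absent. Among these compounds, the narrow spread of the earlier compounds gave no sign that a single change could produce steps of this size, and both steps lead to compound 4.

The compounds shown leave open whether the high response depends on hydrogen at this carbon or would persist with another group there, such as an amine, a fluorine atom or a longer ether chain. Nothing available explains why the maximal response changes so strongly with either replacement.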